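Hydroxy to Dimethylamino on the Aminoethyl Chain of Compound 1

The source may hold more compounds than are shown below. What is called first, only, known or untested is meant among the compounds shown, and "the series" means these compounds.

Going by the values given here, compound 1 `N#Cc1ccc(Cn2nc(-c3cc(Cl)c(NCCO)nc3F)c3ccccc3c2=O)cc1` is the only member of this set with a measured number. In an ADME assay on HepG2 2.2.15 cells (Homo sapiens) for cytotoxicity, read by MTT assay, with a stated time of 8 days (a lower number here means that less compound is tolerated, a higher number that more compound is tolerated), compound 1 gives 32100 nM. Compound 2 `COC(=O)c1cc(-c2ccc(F)nc2F)nn(Cc2ccc(Cl)cc2)c1=O` reaches only a limit of the assay, recorded as > 100000 nM in this assay. Among the compounds with values here, compound 1 therefore stands alone as the single numeric value, the other entry being (the limit of > 100000 nM in this assay, at which 1 of the 2 values shown sits). Within the data shown here, no step between two measured compounds is available, so the step to compound 3 has to be judged from the change itself. Compound 3 `CN(C)CCNc1nc(F)c(-c2nn(Cc3ccc(C#N)cc3)c(=O)c3ccccc23)cc1Cl` differs from compound 1 in one place: dimethylamino in place of hydroxy on a saturated chain carbon, two bonds along the chain from a nitrogen on an aromatic ring. Without a measured pair to lean on, the step in this assay from compound 1 to compound 3 is expected to be modest and toward a lower number, as a 1.6-fold lower number from compound 1 to compound 3 (0.21 log units; within the scatter). Compound 3 is accordingly estimated at 20000 nM, within a range of 8000 nM to 50000 nM.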

Compound 3, half-maximal cytotoxic concentration: 9760 nM
Beside the measured number, compound 3's estimate is 2.0-fold (0.31 log units) above it; the range from low to high includes it.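

In this assay, going by these compounds alone, the exchange of hydroxy for dimethylamino gives the first measured step at this position (a 3.3-fold lower number from compound 1 to compound 3 (0.52 log units; beyond the scatter)). On this saturated chain carbon, two bonds along the chain from a nitrogen on an aromatic ring, the end group of the chain therefore changes how much compound the cells tolerate, and the dimethylamino compound is the one tolerated less. Nothing measured here accounts for this step.

On these data alone, whether the step comes from the arrival of dimethylamino or from the loss of hydroxy stays open. How a primary amine, a methoxy group or a morpholine would fare at the same place is also unknown, as is the effect of a longer chain carrying the dimethylamino group.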